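Aryl variation on the sulfonamide core: compound 4 estimate

A few compounds are considered here, and "the series" means these few. Any claim that something is new, unique, unknown or untested is made for them only; others in the source may bear on it.

Measured compounds in a functional assay on HT-29 cells (Homo sapiens) for inhibition, with a stated time of 72 h; a lower number here means a stronger inhibitor, a higher number a weaker inhibitor:
compound 1 `COc1ccc(S(=O)(=O)N2CCc3cccc(-c4cccnc4)c32)cc1`: 76.3 nM
compound 2 `COc1ccc(S(=O)(=O)N2CCc3cccc(-c4ccc(F)c(F)c4)c32)cc1`: 57 nM
compound 3 `COc1ccc(S(=O)(=O)N2CCc3cccc(-c4ccncc4)c32)cc1`: 87.5 nM

Compound 3 gives the highest of the three numbers in this assay, but its nearest neighbour is compound 1, at a 1.1-fold higher number from compound 1 to compound 3 (0.06 log units; within the scatter), and the furthest is compound 2, at a 1.5-fold higher number from compound 2 to compound 3 (0.19 log units; within the scatter); both of these gaps lie within the scatter, so the three compounds cannot be separated on the numbers shown.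

Compound 4 `COc1ccc(S(=O)(=O)N2CCc3cccc(-c4ccc(N)cc4)c32)cc1` is not yet measured. It differs from compound 3 in this way: 4-aminophenyl in place of pyridin-4-yl on an aromatic carbon.

For the measured compounds named here, the steps that bear on this change are the ones that swap the aromatic group on the same carbon of the shared core: a 1.1-fold higher number from compound 1 to compound 3 (0.06 log units; within the scatter), a 1.3-fold lower number from compound 1 to compound 2 (0.13 log units; within the scatter) and a 1.5-fold higher number from compound 2 to compound 3 (0.19 log units; within the scatter). None of them moves the number beyond the scatter, whether the group is a pyridine ring or a carbon-only ring. The expectation for compound 4 is therefore a step of a 1.3-fold lower number from compound 3 to compound 4 (0.10 log units; within the scatter), that is, no shift beyond the scatter in this assay. Compound 4 is estimated at 70 nM, with a range from 35 nM to 140 nM.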

Compound 4, half-maximal inhibitory concentration: 301 nM
Compound 4: middle estimate off by 4.3-fold (0.63 log units), on the low side; the measured number lies above the stated range.
By their numbers in this assay, from the lowest: compounds 2, 1 and 3 (each within the scatter of the next); then compound 4.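

On the aromatic carbon of the shared core, the group is not freely interchangeable in this assay: 4-aminophenyl gives a 3.4-fold higher number from compound 3 to compound 4 (0.54 log units; beyond the scatter), along with a 3.9-fold higher number from compound 1 to compound 4 (0.60 log units; beyond the scatter) and a 5.3-fold higher number from compound 2 to compound 4 (0.72 log units; beyond the scatter), all beyond the scatter. The tolerance seen among the two pyridine rings and the 3,4-difluorophenyl ring therefore does not extend to every aryl group, and the change from pyridin-4-yl to 4-aminophenyl also brings in a hydrogen-bond donor. No measurement shown accounts for this step.

Going by these compounds, it remains open whether the shift belongs to the amine itself or to the carbon-only ring that carries it. A plain phenyl, an acetamide or a dimethylamino group at this place would help separate these readings.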